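A ring substituent swap on the triazole nitrogen

The compounds below may be only part of what the source reports. "The series", "measured", "known", "first", "only" and "open" are said of these compounds alone.

Compound 2 `Oc1cc(C(F)(F)F)ccc1-c1nc(-c2ccccc2O)n(-c2ccc(I)cc2)n1` is the starting point. Among the compounds with values here, in a functional assay on PC-12 cells (Rattus norvegicus) for cytotoxicity, read by MTT assay, with stated times of 2 h and 24 h, tested at 10 uM (on this read-out lower numbers stand for a weaker effect and higher numbers for a stronger effect at the one concentration tested), compound 2 gives 105%, and its number is the middle one of the three measured so far: compound 3 `COc1cccc(-n2nc(-c3ccc(C(F)(F)F)cc3O)nc2-c2ccccc2O)c1` is nearest, with 106% in this assay, and compound 1 `Cc1ccc(-n2nc(-c3ccc(C(F)(F)F)cc3O)nc2-c2ccccc2O)cc1` is furthest, with 102% in this assay. The three steps among them are all small: a number 3 percentage points higher from compound 1 to compound 2 (within the scatter), a number 1 percentage points higher from compound 2 to compound 3 (within the scatter) and a number 4 percentage points higher from compound 1 to compound 3 (within the scatter).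

Compound 4 `Cc1ccc(-n2nc(-c3ccc(C(F)(F)F)cc3O)nc2-c2ccccc2O)c(C)c1` differs from compound 2 in one place: 2,4-dimethylphenyl in place of 4-iodophenyl on an aromatic nitrogen. Within the data shown here, the steps that bear on this change are those that also alter the group on the aromatic nitrogen, namely a number 3 percentage points higher from compound 1 to compound 2 (within the scatter) and a number 1 percentage points higher from compound 2 to compound 3 (within the scatter), and neither reached beyond the scatter. The account therefore expects no step beyond the scatter in this assay for compound 4, in either direction. The estimated step is a number 2 percentage points lower from compound 2 to compound 4 (within the scatter). Compound 4 is expected to give about 103%, within a range from 92% to 114%.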

Compound 4, a percentage reported as activity, at one concentration (the size of the read-out at that concentration, not a potency): 106%
Compound 4: middle estimate off by 3 percentage points, on the low side; measured number inside the range.
By their numbers in this assay, from the lowest: compounds 1, 2, 3 and 4 (each within the scatter of the next).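

With 2,4-dimethylphenyl on the aromatic nitrogen, this assay shows that a phenyl ring carrying two substituents stays within the scatter of the singly substituted rings (a step of a number 1 percentage points higher from compound 2 to compound 4 (within the scatter) and no change at the digits printed from compound 3 to compound 4 (within the scatter)). The series also gains its first step that changes only one aromatic carbon of this ring, methyl in place of hydrogen (a step of a number 4 percentage points higher from compound 1 to compound 4 (within the scatter)), and that step also stays within the scatter. No measurement shown gives a reason for this flat picture.

As far as these compounds go, all four compounds carry a substituted phenyl ring on that nitrogen, so the effect of a different kind of group there remains open. Whether an amine or a carboxylic acid on the ring, or a longer chain in its place, would move the number beyond the scatter cannot be told from these compounds.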